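Compound 4: sulfo in place of hydrogen on the nitrogen

The compounds below may be only part of what the source reports. "The series", "measured", "known", "first", "only" and "open" are said of these compounds alone.

Values in a physicochemical assay for lipophilicity, measured as octanol-water partition, at pH 7.4 (on this read-out higher numbers stand for higher lipophilicity and lower numbers for lower lipophilicity), with limits marked as such:
compound 1 `Nc1ccc(-c2nc3ccccc3s2)cc1Cl`: limit, > 3.3
compound 2 `Nc1ccc(-c2nc3ccccc3s2)cc1I`: limit, > 3.3
compound 3 `O=S(=O)(O)Nc1ccc(-c2nc3ccccc3s2)cc1Cl`: 0.02

Compound 2 gives > 3.3, which is a limit and not a number. On these data alone, the series shows (the limit of > 3.3 in this assay, at which 2 of the 3 values shown sit), so the true starting point for the step is unknown.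

The step leads to compound 4 `O=S(=O)(O)Nc1ccc(-c2nc3ccccc3s2)cc1I` and puts sulfo in place of hydrogen on a nitrogen on an aromatic ring, the change from amino to sulfoamino: sulfo in place of hydrogen on a nitrogen on an aromatic ring.

The same change has been measured once, with chloro in place of iodo, and gave a number at least 3.28 log units lower from compound 1 to compound 3 (beyond the scatter). That single precedent is large and points downward. The exchange of iodo for chloro on an aromatic carbon gives a step that the two limits leave unreadable from compound 1 to compound 2, so it supplies no size to carry over.

A large fall in this assay is therefore expected, of the same direction as the precedent. Among the compounds with values here, the nearest anchor for the expectation is compound 3 at 0.02, and the range has to stay wide because only that one sulfo compound has a number.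

The estimated change is a number at least 3.10 log units lower from compound 2 to compound 4 (beyond the scatter). Compound 4 is expected at 0.2, with an estimated range from -0.4 to 0.8.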

Compound 4, distribution coefficient: 1.8
Compound 4: middle estimate off by 1.60 log units, on the low side; measured number outside the range, above it.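

In this assay, sulfo in place of hydrogen on the nitrogen again brings the number down with iodo on the aromatic carbon, a number at least 1.50 log units lower from compound 2 to compound 4 (beyond the scatter), so the fall seen with chloro, a number at least 3.28 log units lower from compound 1 to compound 3 (beyond the scatter), now holds in a second pair. Within the data shown here, the halogen exchange also becomes readable for the first time, in the sulfoamino pair: a number 1.78 log units higher from compound 3 to compound 4 (beyond the scatter), which shows that the aromatic carbon still matters to this read-out once the sulfo group is on the nitrogen. The same exchange cannot be read in the amino pair, and the two sulfo steps cannot be compared in size, because both amino compounds give no number: the limit of > 3.3 in this assay, at which 2 of the 4 values shown sit.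

On these data alone, the iodo-over-chloro rise rests on this one pair, so it remains open whether it carries over when the nitrogen bears a different group, such as acetyl or a carboxylic acid chain. As far as these compounds go, it also remains open how bromo or methyl on the same aromatic carbon would read against compound 3 and compound 4 in this assay.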